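A few compounds are considered here, and "the series" means these few. Any claim that something is new, unique, unknown or untested is made for them only; others in the source may bear on it.

Compound 1 `COc1ccc(/C=C\c2cc(OC)c(OC)c(OC)c2)cc1OCc1ccc(CN2CCCC[C@@H]2C(=O)O)cc1`: 42000 nM
Compound 2 `COc1ccc(/C=C\c2cc(OC)c(OC)c(OC)c2)cc1OCc1ccc(CN[C@H](C(=O)O)[C@H](C)O)cc1`: > 50000 nM, a limit of the assay
Compound 3 `COc1ccc(/C=C\c2cc(OC)c(OC)c(OC)c2)cc1OCc1ccc(CN2CCCCC2C(=O)NCCNC(=O)OC(C)(C)C)cc1`: 48000 nM

In an ADME assay on HEK293 cells (Homo sapiens) for cytotoxicity, read by CCK-8 assay, with a stated time of 48 h (a higher number here means a weaker inhibitor, a lower number a stronger inhibitor), compound 1 gives 42000 nM, and compound 3, at 48000 nM, lies within the scatter of it. Compound 4 `COc1ccc(/C=C\c2cc(OC)c(OC)c(OC)c2)cc1OCc1ccc(CO)cc1` has hydroxy in place of 2-carboxypiperidin-1-yl on a saturated chain carbon bound to an aromatic carbon. Going by the values given here, the one measured step at this place is an at least 1.1-fold higher number from compound 1 to compound 2 (0.07 log units; that floor lies within the scatter). It replaces the same group but keeps a far larger one, so it guides only loosely. A modest move towards a lower number in this assay is expected, namely a 1.7-fold lower number from compound 1 to compound 4 (0.23 log units; within the scatter). For compound 4 the estimate is 25000 nM, with an expected range from 3000 nM to 60000 nM.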

Compound 4, half-maximal inhibitory concentration: 37000 nM
Compound 4: the middle estimate sits 1.5-fold (0.17 log units) below what was measured, within the range that was stated.
By their numbers in this assay, from the lowest: compounds 4, 1 and 3 (each within the scatter of the next). At a limit, above all of these: compound 2.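

Hydroxy, with no ring and far fewer heavy atoms, can take the place of 2-carboxypiperidin-1-yl on this saturated chain carbon with no shift beyond the scatter in this assay (a 1.1-fold lower number from compound 1 to compound 4 (0.06 log units; within the scatter)). Against the (1-carboxy-2-hydroxypropyl)amino group, the comparison yields only a floor (an at least 1.3-fold lower number from compound 2 to compound 4 (0.13 log units; that floor lies within the scatter)). Compound 2 stands at a limit, not at a number: the limit of > 50000 nM in this assay, at which 1 of the 4 values shown sits.

On these data alone, whether any group at this place can move the number beyond the scatter remains open. A primary amine or a methyl ether here would test this on the shared core.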